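The compounds below may be only part of what the source reports. "The series", "measured", "known", "first", "only" and "open" are said of these compounds alone.

Compound 2, drawn as `COc1ccc(C(=O)Nc2nc3cc(C)cc(C)c3s2)cc1`, is an amide built on the shared core, and in a functional assay on MDA-MB-231 cells (Homo sapiens) for antiproliferative activity, read by sulforhodamine B assay (on this read-out higher numbers stand for weaker inhibition of growth and lower numbers for stronger inhibition of growth), compound 2 gives 1.03 ug/mL. Compound 1, drawn as `O=C(Nc1cccc([N+](=O)[O-])c1)Nc1nc2ccc(Cl)cc2s1`, is a urea on a related core, and in this assay compound 1 gives 0.82 ug/mL, a number that sits within the usual scatter of the number for compound 2, so the two cannot be told apart on these data. Compound 3, drawn as `COc1ccc2sc(NC(=O)c3ccc(C)cc3)nc2c1`, reaches only a limit of this assay, namely > 10 ug/mL, and this is a limit rather than a measured number, as noted in the limit of > 10 ug/mL in this assay, at which 1 of the 3 values shown sits. Compound 4, drawn as `Cc1cc(C)c2sc(NC(=O)c3ccc(C#N)cc3)nc2c1`, has not yet been measured. It differs from compound 2 in one place: cyano in place of methoxy on an aromatic carbon. Going by the values given here, no measured pair shows what such an exchange does in this assay, so the expectation rests on compound 2 alone. The step from compound 2 to compound 4 is expected to be small, within or near the scatter, as a 1.5-fold higher number from compound 2 to compound 4 (0.16 log units; within the scatter) shows. Compound 4 is therefore expected to give about 1.5 ug/mL, with a range from 0.5 ug/mL to 6 ug/mL.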

Compound 4, concentration for 50% growth inhibition: 0.48 ug/mL
For compound 4 the middle estimate is 3.1-fold (0.49 log units) above the measured one, and the stated range ends above it.
By their numbers in this assay, from the lowest: compounds 4, 1 and 2 (each within the scatter of the next, the first and the last beyond it). At a limit, above all of these: compound 3.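

Going by these compounds alone, this is the first measured exchange at this position, para to a large group, and it gives a 2.1-fold lower number from compound 2 to compound 4 (0.33 log units; beyond the scatter) in this assay, a modest step just beyond the scatter. The position therefore accepts cyano in place of methoxy with no loss of growth inhibition, and the number still moves even though the two groups match in heavy atoms and hydrogen-bond acceptors, so those counts alone do not set it. This rests on a single pair, so it describes one exchange and not a trend.

From the compounds shown here alone, whether an amine, a carboxylic acid or a longer chain at this position would lower the number further, or raise it, remains open. Nothing among the results shown explains why this exchange moves the number in this direction.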